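The compounds below may be only part of what the source reports. "The series", "measured", "known", "first", "only" and "open" are said of these compounds alone.

Measured compounds in a functional assay on KB cells (Homo sapiens) for inhibition, read by MTT assay, with a stated time of 24 h, tested at 10 ug/mL; a lower number here means less inhibition of growth, a higher number more inhibition of growth at the concentration tested:
compound 1, `O=C(CCCCC(S)CCS)Nc1ccccn1`, gives 0.28%
compound 2, `O=C(CCCCC(S)CCS)Nc1ccc(Cl)cn1`, gives 21.6%
compound 3, `CC(=O)SCCC(CCCCC(=O)Nc1ccccc1)SC(C)=O`, gives 2.5%

Compound 2 differs from compound 1 by chloro in place of hydrogen on an aromatic carbon. Going by the values given here, the step is a number 21.3 percentage points higher from compound 1 to compound 2 (beyond the scatter), the only change so far that is beyond the scatter.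

Compound 3 carries a different core; the difference between the core of compound 1 and the core of compound 3 is not broken down here. Compound 3 and compound 1 lie within the scatter of each other, so no order between them is read. Against compound 2, compound 3 stands lower, and that gap is beyond the scatter.

Compound 4, `CC(=O)SCCC(CCCCC(=O)Nc1ccccc1Cl)SC(C)=O`, is not yet measured in this assay. It differs from compound 3 by chloro in place of hydrogen on an aromatic carbon. This is the same kind of change as from compound 1 to compound 2, not the same change: in compound 2 the chloro sits on a six-membered aromatic ring with 1 nitrogen, two atoms from the ring nitrogen and para to a large group, while in compound 4 it sits on a six-membered aromatic ring of carbon only, ortho to a large group.

For compound 4 a step of a number 11.5 percentage points higher from compound 3 to compound 4 (beyond the scatter) is expected; this expectation rests on the measured step of a number 21.3 percentage points higher from compound 1 to compound 2 (beyond the scatter), with the difference in place leaving it uncertain. Compound 4 is estimated at 14%, with a range from 0% to 32%.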

Compound 4, percent growth inhibition at one concentration: 6.55%
Compound 4: the middle estimate sits 7.5 percentage points above what was measured; the measured number falls inside the stated range.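

In this assay, chloro in place of hydrogen on an aromatic carbon does not carry over at the same size from one core to the other: the same change on two cores in this assay, a number 21.3 percentage points higher (beyond the scatter) from compound 1 to compound 2 and a number 4.1 percentage points higher (within the scatter) from compound 3 to compound 4, 17.3 percentage points apart, beyond the scatter of two such steps

On the core of compound 3 the change gives a number 4.1 percentage points higher from compound 3 to compound 4 (within the scatter), so no order is read between these two compounds, and the step seen on the core of compound 1 cannot be assumed to transfer to this core. What this does not show is which difference between the two pairs sets the steps apart: they differ in the aromatic ring that carries the chloro, in the place of the chloro on that ring, and in free thiol against acetylated sulfur groups, and with a single pair on each core these cannot be separated.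

Open, as far as these compounds go, is whether chloro at another place on the phenyl ring of the core of compound 3 would give a step beyond the scatter, and whether removing the acetyl groups from sulfur would change the size of the step. Also open, from the compounds shown here alone, is how a group other than chloro, such as methoxy or a carboxylic acid, would read on either core.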